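The source may report more compounds than this note shows. Statements on the series, on what has been measured and on what is new or still open speak of the compounds shown alone.

Measured so far:
compound 1 `CCCN(CCC)c1c(C)nc(-c2c(C)cc(C)cc2OC)c2ccccc12` — 6 nM
compound 2 `CCCN(CCC)c1cnc(-c2c(C)cc(C)cc2OC)nc1C` — 561 nM

Of the compounds shown here, two have been measured in an in vitro assay on IMR-32 cells for displacement of a labelled ligand from corticotropin-releasing factor receptor 1 (Homo sapiens); on this read-out higher numbers stand for weaker inhibition and lower numbers for stronger inhibition. Compound 1 gives 6 nM in this assay, while compound 2, built on a different core, gives 561 nM. Compound 2 therefore stands with the highest number of the two, and the gap to compound 1 is far beyond the usual scatter, so compound 2 is clearly the weaker binder of the pair. The two cores differ in more than one place. The numbers say nothing about which single feature accounts for that gap.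

Compound 3 `CCCN(CCC)c1c(C)nc(-c2c(C)cc(C)cc2OC)nc1OC` keeps the core of compound 2 and changes it in one place: methoxy in place of hydrogen on an aromatic carbon. Going by the values given here, no measured pair shows what this particular addition does on this core, so there is no step to lean on. The expectation for compound 3 is a modest move rather than a large one, with the estimated step from compound 2 to compound 3 in this assay being a 2.2-fold lower number from compound 2 to compound 3 (0.35 log units; beyond the scatter). On that basis compound 3 is expected to give about 250 nM in this assay, plausibly anywhere between 40 nM and 1500 nM.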

Compound 3, inhibition constant: 15 nM
Compound 3: the middle estimate sits 17-fold (1.22 log units) above what was measured; measured number outside the range, below it.
By their numbers in this assay, from the lowest: compound 1; then compound 3; then compound 2.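

In this assay, putting a methoxy group on this aromatic carbon, next to the ring nitrogen and ortho to a dipropylamino group, gives a 37-fold lower number from compound 2 to compound 3 (1.57 log units; beyond the scatter) and that step is large. The position therefore matters a great deal for this read-out: in compound 2 it carries only a hydrogen atom, and a group of just 2 heavy atoms in that place is enough to shift the number far beyond the usual scatter of repeated measurements. Nothing among the data shown explains why this one change has so strong an effect.

A single change at a single position cannot say whether the gain belongs to methoxy in particular or whether other groups on the same carbon, such as an ethoxy group or a chlorine atom, would do as well, better or worse. Going by these compounds, it also stays open what an amine or a hydroxyl group in that place would do to the number, and whether anything larger than methoxy would still be tolerated there.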